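This account rests on a few compounds, and the source may have more. Where it says the series, first, only, none or still open, it means among the compounds named here.

Measured compounds:
- Compound 1 `COc1c(NS(=O)(=O)c2ccc(F)cc2)cc(-c2ccc3nc(NC4CC4)sc3n2)cc1C(N)=O`: 33100 nM
- Compound 2 `COc1c(NS(=O)(=O)c2ccc(F)cc2)cc(-c2ccc3nc(NC(C)=O)sc3c2)cc1C(N)=O`: 500 nM
- Compound 3 `COc1c(NS(=O)(=O)C2CC2)cc(-c2ccc3nc(NC(C)=O)nn3c2)cc1C(N)=O`: "not determined" (no result reported)

In a functional assay on MCF7 cells (Homo sapiens) for antiproliferative activity, read by MTT assay, with a stated time of 72 h (a lower number here means a stronger inhibitor, a higher number a weaker inhibitor), compound 1 gives 33100 nM, the highest of the two numbers recorded, meaning it is the weaker of the two inhibitors. Compound 2 gives 500 nM, a much lower number that lies well beyond the usual scatter of this assay. Compound 3 has no value in this assay, so it adds nothing to the comparison.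

Compound 4 `COc1c(NS(=O)(=O)c2ccc(F)cc2)cc(-c2ccc3nc(NC(C)=O)sc3n2)cc1C(N)=O` has not yet been measured. It differs from compound 1 in one place: acetyl in place of cyclopropyl on a nitrogen on an aromatic ring, that is, cyclopropylamino becomes acetamido. Among the measured compounds shown here, no measured pair differs by exactly this change, so the size of the step has to be guessed. Compound 2 also carries an acetamido group on its own core and gives 500 nM, which is the only hint available, and it points toward a lower number. The step from compound 1 to compound 4 is therefore expected to be a 13-fold lower number from compound 1 to compound 4 (1.12 log units; beyond the scatter), a drop beyond the scatter. Compound 4 is estimated at 2500 nM, within a range from 400 nM to 16000 nM.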

Compound 4, half-maximal inhibitory concentration: 12500 nM
The estimate for compound 4 lay 5.0-fold (0.70 log units) below the measured number; the measured number falls inside the stated range.
By their numbers in this assay, from the lowest: compound 2; then compound 4; then compound 1.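

In this assay, among the compounds shown here, the change from cyclopropylamino to acetamido on the shared core gives a 2.6-fold lower number from compound 1 to compound 4 (0.42 log units; beyond the scatter), the first reading of any single change in this set, and it shows that the group on this nitrogen does affect the number. The step is beyond the scatter but modest, and it leaves compound 4 at 12500 nM, still a higher number than compound 2 at 500 nM, which carries the same acetamido group on a core of its own, so having acetamido in this place does not by itself bring a compound down to that lower number. Nothing measured here explains why the acetyl group gives the lower number than the cyclopropyl group.

On these data alone, with one replacement read at this nitrogen, it remains open how a free amine, a longer chain such as butanoyl, or a urea would compare with acetamido. As far as these compounds go, it is also open whether the same swap would give a step of similar size on the core of compound 2, since a single pair cannot show whether the change behaves the same way elsewhere.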